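Swapping trifluoromethyl for (ethoxycarbonyl)methoxy

The compounds below may be only part of what the source reports. "The series", "measured", "known", "first", "only" and "open" are said of these compounds alone.

Measured so far in a functional assay on FaDu cells (Homo sapiens) for cytotoxicity, read by MTT assay, with a stated time of 72 h; on this read-out lower numbers stand for higher toxicity in this test and higher numbers for lower toxicity in this test:
Compound 1 `COCCn1cc(C(=O)C(=O)Nc2ccc(OCC(=O)O)nc2)c2ccccc21` gives > 10000 nM
Compound 2 `COCCn1cc(C(=O)C(=O)Nc2ccc(OC(C)(C)C)nc2)c2ccccc21` gives 858 nM
Compound 3 `COCCn1cc(C(=O)C(=O)Nc2ccc(C(F)(F)F)nc2)c2ccccc21` gives > 10000 nM

Compound 3 stands at > 10000 nM, which is a limit and not a number. Only compound 2 falls clear of the limit of > 10000 nM in this assay, at which 2 of the 3 values shown sit.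

Compound 4 `CCOC(=O)COc1ccc(NC(=O)C(=O)c2cn(CCOC)c3ccccc23)cn1` keeps the shared core but carries (ethoxycarbonyl)methoxy in place of trifluoromethyl on an aromatic carbon. For the measured compounds named here, two measured steps bear on this change, and both are large. One is an at least 11-fold lower number from compound 1 to compound 2 (1.06 log units; beyond the scatter), and the other is an at least 11-fold higher number from compound 2 to compound 3 (1.06 log units; beyond the scatter). Together they show that a swap at this place can move the number a long way. An oxygen link alone offers no assurance of this, since compound 1 has one and reads > 10000 nM, again a limit. Going by the values given here, a lower number is therefore expected for compound 4, though probably a smaller drop than the one seen with compound 2, and the result may still be only a limit. The expected change is an at least 3.3-fold lower number from compound 3 to compound 4 (0.52 log units; beyond the scatter). The estimate for compound 4 is 3000 nM, with an expected range of 700 nM to 10000 nM.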

Compound 4, concentration lethal to 50% of the cells: > 10000 nM
Compound 4: only a limit was reported; the forecaster's own chance of this, stated with the estimate: 40%; middle value at least 3.3-fold (0.52 log units) away from the limit.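

Putting (ethoxycarbonyl)methyl in place of tert-butyl on the oxygen gives an at least 11-fold higher number from compound 2 to compound 4 (1.06 log units; beyond the scatter) in this assay. The low number of compound 2 therefore does not carry over to every group joined through that oxygen, and compound 2 is now the only one of the four that reads as a number. The steps joining compound 4 to compound 1 and to compound 3 cannot be read, as both ends of each are limits and not numbers: the limit of > 10000 nM in this assay, at which 3 of the 4 values shown sit.

Compound 2 gives 858 nM as its value. The compounds shown leave open whether isopropyl or methyl on the same oxygen would give a number close to this one or would read as a limit. Also open, on these data alone, is how an amine at this place would read.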